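Swapping methoxy for cyano on the triazole-linked phenyl ring

A few compounds are considered here, and "the series" means these few. Any claim that something is new, unique, unknown or untested is made for them only; others in the source may bear on it.

Three compounds share one core, a cinnamic acid bearing a prenyl chain and a triazole-linked aryl group. Compound 1 `COc1ccc(/C=C\C(=O)O)c(OCc2cn(-c3ccccc3F)nn2)c1CC=C(C)C` has no reported result in a functional assay on HCT-116 cells (Homo sapiens) for cytotoxicity, read by MTT assay, with a stated time of 24 h; on this read-out lower numbers stand for stronger inhibition and higher numbers for weaker inhibition: for compound 1 the entry reads "not determined" (no result reported). Within the data shown here, compound 2 `COc1cccc(-n2cc(COc3c(/C=C\C(=O)O)ccc(OC)c3CC=C(C)C)nn2)c1` gives the only number so far: in this assay compound 2 reaches 21600 nM, a weak effect, and it stands alone, with nothing to rank it against.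

Compound 3 `COc1ccc(/C=C\C(=O)O)c(OCc2cn(-c3cccc(C#N)c3)nn2)c1CC=C(C)C` differs from compound 2 in one spot: cyano in place of methoxy on an aromatic carbon. Among the measured compounds shown here, no measured pair shows what such a swap does here, so the outlook rests on one value. A change of this kind is expected to move the result little, and the step from compound 2 to compound 3 is estimated at a 1.2-fold lower number from compound 2 to compound 3 (0.08 log units; within the scatter), within the usual scatter, in no clear direction. Compound 3 is therefore expected to give about 18000 nM in this assay, with a likely range from 6000 nM to 50000 nM.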

Compound 3, half-maximal inhibitory concentration: 35300 nM
Beside the measured number, compound 3's estimate is 2.0-fold (0.29 log units) below it, within the range that was stated.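

In this assay, putting cyano in place of methoxy gives a 1.6-fold higher number from compound 2 to compound 3 (0.21 log units; within the scatter) and so does not separate the 3-methoxyphenyl and 3-cyanophenyl compounds on this read-out. This first measured pair shows that, on this aromatic carbon, the two groups cannot be told apart, even though one carries an oxygen and the other a triple bond to nitrogen. No supporting measurement is available to explain this result.

Open, from the compounds shown here alone, is whether a different group at this place, such as an amine, a carboxylic acid or a longer alkoxy chain, would shift the number beyond the scatter. A single pair also cannot show whether the swap from methoxy to cyano would read the same way on a different core.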